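From thiophen-2-yl to phenyl on a carbonyl carbon

The source may report more compounds than this note shows. Statements on the series, on what has been measured and on what is new or still open speak of the compounds shown alone.

Measured so far in an ADME assay on HepG2 2.2.15 cells (Homo sapiens) for cytotoxicity, read by MTT assay (on this read-out higher numbers stand for lower toxicity in this test and lower numbers for higher toxicity in this test), are two compounds:
Compound 1 `C=C1CC[C@@H]2[C@](C)(CO)[C@H](OC(=O)/C=C/c3ccccc3)CC[C@@]2(C)[C@@H]1C/C=C1\C=COC1=O` gives 179000 nM here
Compound 2 `C=C1CC[C@@H]2[C@](C)(CO)[C@H](OC(=O)c3cccs3)CC[C@@]2(C)[C@@H]1C/C=C1\C=COC1=O` gives 257000 nM here

Compound 2 at 257000 nM stands level with compound 1 within the scatter, and these two numbers are all that is at hand. Compound 3 `C=C1CC[C@@H]2[C@](C)(CO)[C@H](OC(=O)c3ccccc3)CC[C@@]2(C)[C@@H]1C/C=C1\C=COC1=O` brings the change phenyl in place of thiophen-2-yl on a carbonyl carbon and so carries phenyl in place of thiophen-2-yl on a carbonyl carbon. Among the measured compounds shown here, the one measured step that bears on this is a 1.4-fold higher number from compound 1 to compound 2 (0.16 log units; within the scatter) at the same place, and it lies within the scatter. A single step is thin evidence, but no step beyond the scatter is expected in this assay for this exchange. The expected step is a 1.2-fold lower number from compound 2 to compound 3 (0.09 log units; within the scatter) as an estimate only. For compound 3 the estimated value is 210000 nM with an expected range from 115000 nM to 380000 nM on this reasoning.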

Compound 3, half-maximal cytotoxic concentration: 103000 nM
Compound 3: the middle estimate sits 2.0-fold (0.31 log units) above what was measured; the whole stated range lies above it.
By their numbers in this assay, from the lowest: compounds 3, 1 and 2 (each within the scatter of the next, the first and the last beyond it).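

In this assay, among the compounds shown here, the group on this carbonyl carbon can move the read-out after all: phenyl in place of thiophen-2-yl gives a 2.5-fold lower number from compound 2 to compound 3 (0.40 log units; beyond the scatter) and is the first step here to clear the scatter, though only modestly. The other new step, a 1.7-fold lower number from compound 1 to compound 3 (0.24 log units; within the scatter), stays within the scatter, so phenyl and 2-phenylethenyl cannot be told apart at this place, and only the thiophen-2-yl and phenyl compounds separate. No measurement at hand explains that separation.

On these data alone, the effect rests on a single pair, so it remains open whether it would hold on any other core. Also open, as far as these compounds go, is how a longer alkyl chain on this carbonyl carbon, or a phenyl carrying an amine or a carboxylic acid, would read in this assay.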